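Replacing the Amide Ring on a Thyroid Hormone Receptor Binder

The source may report more compounds than this note shows. Statements on the series, on what has been measured and on what is new or still open speak of the compounds shown alone.

Compound 1 `COc1cc(C(=O)N2CCC(O)C(C)C2)cc2nc(N[C@H](C)c3cccc(Cl)c3)oc12`: 48 nM
Compound 2 `COc1cc(C(=O)N2CCC(O)C(C)C2)cc2nc(NC3(c4cccc(Cl)c4)CCC3)oc12`: 8200 nM

In an assay on isolated protein for inhibition of thyroid hormone receptor beta (Homo sapiens), read by fluorescence, with a stated time of 30 min (a lower number here means a stronger inhibitor, a higher number a weaker inhibitor), compound 1 gives 48 nM, the lowest number of the two measured compounds. Its nearest neighbour is compound 2, where the step of a 170-fold higher number from compound 1 to compound 2 (2.23 log units; beyond the scatter) shows how strongly the nitrogen-attached group of the shared core of compound 1 governs the result.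

Compound 3 `COc1cc(C(=O)N2C[C@@H](C)OC[C@H]2CCO)cc2nc(N[C@H](C)c3cccc(Cl)c3)oc12` differs from compound 1 on the other side of the core: 5-(2-hydroxyethyl)-2-methylmorpholin-4-yl in place of 4-hydroxy-3-methylpiperidin-1-yl on a carbonyl carbon. Within the data shown here, no measured step touches the amide side of the core, so the step from compound 1 to compound 2 does not bear on this change directly; it shows only that the numbers in this assay can move far. The entering group is a little larger than the leaving one and keeps one hydrogen-bond donor, so a change well within the scatter, or a small rise, is expected: a 1.7-fold higher number from compound 1 to compound 3 (0.22 log units; within the scatter). Compound 3 is estimated at 80 nM, with a range of 25 nM to 300 nM.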

Compound 3, half-maximal inhibitory concentration: 6 nM
For compound 3 the middle estimate is 13-fold (1.12 log units) above the measured one; the whole stated range lies above it.
By their numbers in this assay, from the lowest: compound 3; then compound 1; then compound 2.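

The amide side of the shared core proves to be a place where the number in this assay can fall: there is an 8.0-fold lower number from compound 1 to compound 3 (0.90 log units; beyond the scatter), with the group on the nitrogen unchanged. Among these compounds, until now, the only reading of a change was on that nitrogen, where a 170-fold higher number from compound 1 to compound 2 (2.23 log units; beyond the scatter), so this step adds a second position at which the number responds, here by a modest amount and towards a lower value. The 5-(2-hydroxyethyl)-2-methylmorpholin-4-yl group differs from 4-hydroxy-3-methylpiperidin-1-yl in several ways at once, including its second ring hetero atom, its 2-hydroxyethyl chain and its 2 defined stereocentres, and no measurement available here ties the step to any of these.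

Going by these compounds, it remains open which of those differences carries the step, and whether a carboxylic acid, an amine or a longer chain in place of the 2-hydroxyethyl chain would keep the number this low. Also open, on these data alone, is how the 5-(2-hydroxyethyl)-2-methylmorpholin-4-yl group would behave with the 1-(3-chlorophenyl)cyclobutyl group on the nitrogen, since a single pairing cannot show whether the two changes act independently.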